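The source may report more compounds than this note shows. Statements on the series, on what has been measured and on what is new or still open speak of the compounds shown alone.

Measured compounds:
compound 1, `CCOC(=O)c1cnn(-c2nc(-c3ccc(OC)cc3)c(C#N)c(=O)n2C)c1N`, 74 ug/mL
compound 2, `CCOC(=O)c1cnn(-c2nc(-c3cccc(O)c3O)c(C#N)c(=O)n2C)c1N`, 53 ug/mL
compound 3, `CCOC(=O)c1cnn(-c2nc(-c3ccc(N(C)C)cc3)c(C#N)c(=O)n2C)c1N`, 119 ug/mL

All three share one core and differ only in the aromatic group attached to it. In a functional assay, with a stated time of 10 min (a higher number here means a weaker inhibitor, a lower number a stronger inhibitor), compound 3 gives the highest number of the three: the nearest step is a 1.6-fold higher number from compound 1 to compound 3 (0.21 log units; within the scatter), the furthest is a 2.2-fold higher number from compound 2 to compound 3 (0.35 log units; beyond the scatter). Compound 4 `CCOC(=O)c1cnn(-c2nc(-c3ccco3)c(C#N)c(=O)n2C)c1N` has not been measured; it differs from compound 3 in one place: furan-2-yl in place of 4-(dimethylamino)phenyl on an aromatic carbon. Within the data shown here, the steps that bear on this exchange of the aromatic group, a 1.4-fold lower number from compound 1 to compound 2 (0.14 log units; within the scatter) and a 2.2-fold higher number from compound 2 to compound 3 (0.35 log units; beyond the scatter), were both small, so only a small shift in either direction is expected here, likely none beyond the scatter; the expected step is a 1.3-fold lower number from compound 3 to compound 4 (0.12 log units; within the scatter). Compound 4 is therefore estimated at 90 ug/mL, with a range from 45 ug/mL to 180 ug/mL.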

Compound 4, half-maximal inhibitory concentration: 104 ug/mL
Compound 4: the middle estimate sits 1.2-fold (0.06 log units) below what was measured, and the stated range covers the measured number.
By their numbers in this assay, from the lowest: compounds 2, 1, 4 and 3 (each within the scatter of the next, the first and the last beyond it).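

Swapping the six-membered aromatic ring for the smaller five-membered furan-2-yl leaves the number in this assay within the scatter of all three earlier compounds (a 1.1-fold lower number from compound 3 to compound 4 (0.06 log units; within the scatter); a 1.4-fold higher number from compound 1 to compound 4 (0.15 log units; within the scatter); a 2.0-fold higher number from compound 2 to compound 4 (0.29 log units; within the scatter)). So this position accepts a ring with a hetero atom and fewer heavy atoms, and compound 4 sits within the scatter of both compound 2 and compound 3, the only pair separated beyond it. No measurement here offers a reason for these small steps.

From the compounds shown here alone, it remains open whether a non-aromatic group such as piperidine, or a phenyl ring carrying a carboxylic acid, would move the number clearly outside this narrow band.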